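The source may hold more compounds than are shown below. What is called first, only, known or untested is meant among the compounds shown, and "the series" means these compounds.

Compound 1 `Cc1ccc(C(=O)NNc2c(Cl)cccc2Cl)cc1`: > 100000 nM, a limit of the assay
Compound 2 `CCCc1ccc(C(=O)NNc2c(Cl)cccc2Cl)cc1`: > 100000 nM, a limit of the assay

The two compounds were tested in a toxicity assay on MDCK cells (Canis lupus familiaris) for cytotoxicity, read by CCK-8 assay, with a stated time of 48 h; on this read-out higher numbers stand for lower toxicity in this test and lower numbers for higher toxicity in this test. Compound 2 has no exact value and stands only at its limit of > 100000 nM. It shares this position with compound 1, as the limit of > 100000 nM in this assay, at which 2 of the 2 values shown sit, shows.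

Compound 3 `CN(C)c1ccc(C(=O)NNc2c(Cl)cccc2Cl)cc1` is still unmeasured. It has dimethylamino in place of propyl on an aromatic carbon.

For the measured compounds named here, only one measured step bears on this change, a step that the two limits leave unreadable from compound 1 to compound 2. Its size cannot be read, so it offers only weak guidance, and it involved no exchange of carbon for nitrogen. No step beyond the scatter is therefore expected in this assay, and no direction can be argued. The expected step is a number no higher from compound 2 to compound 3 (the limit leaves the size open). Compound 3 is estimated at 100000 nM, with an expected range of 35000 nM to 200000 nM.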

Compound 3, half-maximal cytotoxic concentration: > 100000 nM
Compound 3 was reported as a limit (the forecaster's own chance of this, stated with the estimate: 75%); the middle value sits exactly at the limit.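

No step can be read among compound 1, compound 2 and compound 3 in this assay, since each value is a limit of the assay: the limit of > 100000 nM in this assay, at which 3 of the 3 values shown sit.

The compounds shown leave open whether propyl, methyl or dimethylamino on the shared core makes any difference to the read-out.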